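Acyl group variation on a shared core: working notes

A few compounds are considered here, and "the series" means these few. Any claim that something is new, unique, unknown or untested is made for them only; others in the source may bear on it.

Measured so far in an assay on HeLa cells for inhibition of DNA topoisomerase 1 (Homo sapiens); a higher number here means a weaker inhibitor, a lower number a stronger inhibitor:
- Compound 1, `CCC/C=C/C(=O)O[C@H](CC=C(C)C)C1=CC(=O)c2c(O)ccc(O)c2C1=O`, gives 153000 nM
- Compound 2, `C/C=C/C=C/C(=O)O[C@H](CC=C(C)C)C1=CC(=O)c2c(O)ccc(O)c2C1=O`, gives 130000 nM
- Compound 3, `CCCCCCC(=O)O[C@H](CC=C(C)C)C1=CC(=O)c2c(O)ccc(O)c2C1=O`, gives 625000 nM

Compound 3 stands highest of the three numbers in this assay. Its distance from compound 1 is a 4.1-fold higher number from compound 1 to compound 3 (0.61 log units; beyond the scatter) and from compound 2 a 4.8-fold higher number from compound 2 to compound 3 (0.68 log units; beyond the scatter); both steps lie beyond the scatter, so compound 3 is the weakest of the three in this assay. The two unsaturated esters, compound 1 and compound 2, sit within the scatter of each other (a 1.2-fold lower number from compound 1 to compound 2 (0.07 log units; within the scatter)).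

Compound 4, `CC(C)=CC[C@@H](OC(=O)C=C(C)C)C1=CC(=O)c2c(O)ccc(O)c2C1=O`, is not yet measured. Relative to compound 3 the change is 2-methylprop-1-en-1-yl in place of hexyl on a carbonyl carbon. Among the measured compounds shown here, the steps that bear on it are the two leading into compound 3, a 4.1-fold higher number from compound 1 to compound 3 (0.61 log units; beyond the scatter) and a 4.8-fold higher number from compound 2 to compound 3 (0.68 log units; beyond the scatter), where a saturated hexyl on the carbonyl carbon gave a clearly higher number than either unsaturated chain. Compound 4 reverses that: an unsaturated chain again sits on the carbonyl carbon. A modest lowering of the number in this assay is therefore expected, of about the size seen in those two steps, as a 3.9-fold lower number from compound 3 to compound 4 (0.59 log units; beyond the scatter). For compound 4 the estimate in this assay is 160000 nM, with a range from 70000 nM to 400000 nM.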

Compound 4, half-maximal inhibitory concentration: 77000 nM
The estimate for compound 4 lay 2.1-fold (0.32 log units) above the measured number; the measured number falls inside the stated range.
By their numbers in this assay, from the lowest: compounds 4, 2 and 1 (each within the scatter of the next); then compound 3.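

In this assay, among the compounds shown here, the swap of hexyl for 2-methylprop-1-en-1-yl on the carbonyl carbon gives an 8.1-fold lower number from compound 3 to compound 4 (0.91 log units; beyond the scatter), the largest step so far, and it comes from a group with fewer heavy atoms and one double bond outside aromatic rings. The two remaining steps, a 1.7-fold lower number from compound 2 to compound 4 (0.23 log units; within the scatter) and a 2.0-fold lower number from compound 1 to compound 4 (0.30 log units; within the scatter), place this third unsaturated group level with penta-1,3-dien-1-yl and pent-1-en-1-yl, so three differently shaped unsaturated groups now form one cluster at this position, and hexyl in compound 3 alone stands apart from it. No measurement is available that would explain this difference between hexyl and the unsaturated groups.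

The step from compound 3 to compound 4 changes chain size and saturation together, so the compounds shown cannot tell which of the two goes with the lower number; a saturated 2-methylpropyl group on the same carbonyl carbon would separate them. Also open, on these data alone, is how this position responds to a group carrying an amine or a carboxylic acid, or to a longer unsaturated chain.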